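Methyl on the Aromatic Carbon of Compound 1

A few compounds are considered here, and "the series" means these few. Any claim that something is new, unique, unknown or untested is made for them only; others in the source may bear on it.

Compound 1 `Clc1ccc2[nH]cc(SC3CCNCC3)c2c1` gives 0.3 mg/kg in a functional assay on the whole organism with Mus musculus as the target, in the writhing test (a lower number here means that less compound is needed, a higher number that more compound is needed for the effect), the lowest number among the three measured compounds. Compound 2 `CC(=O)N1CCC(Sc2c[nH]c3ccc(Cl)cc23)CC1` gives 2.9 mg/kg and compound 3 `CCCC(=O)N1CCC(Sc2c[nH]c3ccc(Cl)cc23)CC1` gives 8.9 mg/kg; the measured steps are a 9.7-fold higher number from compound 1 to compound 2 (0.99 log units; beyond the scatter) and a 30-fold higher number from compound 1 to compound 3 (1.47 log units; beyond the scatter), with a 3.1-fold higher number from compound 2 to compound 3 (0.49 log units; beyond the scatter) between the two acylated compounds. Compound 4 `Cc1[nH]c2ccc(Cl)cc2c1SC1CCNCC1` differs from compound 1 by methyl in place of hydrogen on an aromatic carbon. Among the compounds with values here, no measured step bears directly on this change: all three measured compounds differ only at the amine nitrogen in the ring, and none varies the aromatic carbon. The expected step in this assay is therefore small, a 1.7-fold higher number from compound 1 to compound 4 (0.22 log units; within the scatter), and could fall in either direction. Compound 4 is estimated at 0.5 mg/kg, with a range from 0.15 mg/kg to 2 mg/kg.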

Compound 4, dose for half-maximal effect: 0.8 mg/kg
Beside the measured number, compound 4's estimate is 1.6-fold (0.20 log units) below it; measured number inside the range.
By their numbers in this assay, from the lowest: compound 1; then compound 4; then compound 2; then compound 3.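

In this assay, methyl in place of hydrogen on the aromatic carbon next to the ring nitrogen gives a 2.7-fold higher number from compound 1 to compound 4 (0.43 log units; beyond the scatter), so this position is not neutral, even for a group of 1 heavy atom. It is also the first measured change away from the amine nitrogen in the ring, showing that the number responds to a change at this second site. No evidence bearing on the cause of this step is available. From the compounds shown here alone, whether ethyl or hydroxymethyl on this aromatic carbon would move the number further stays open, as does how methyl here would combine with acetyl on the amine nitrogen.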